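Replacing hydroxy with ethylamino on a potent compound

The source may report more compounds than this note shows. Statements on the series, on what has been measured and on what is new or still open speak of the compounds shown alone.

- compound 1 `CCNCC(=O)Nc1cc(OC)ccc1C(=O)c1ccc(OC)c2c1C=CC(C)(C)O2` gives 4090 nM
- compound 2 `COc1ccc(C(=O)c2cc(OC)c(OC)c(OC)c2)c(NC(=O)CO)c1` gives 100 nM

In a functional assay on A2780 cells (Homo sapiens) for antiproliferative activity, read by MTT assay, with a stated time of 48 h (a lower number here means a stronger inhibitor, a higher number a weaker inhibitor), compound 2, at 100 nM, holds the lower of the two numbers, and the gap to compound 1 lies beyond the scatter. Compound 3 `CCNCC(=O)Nc1cc(OC)ccc1C(=O)c1cc(OC)c(OC)c(OC)c1` differs from compound 2 by ethylamino in place of hydroxy on a saturated chain carbon bound to a carbonyl carbon. For the measured compounds named here, no measured pair shows this change alone. Compound 1 also carries ethylamino and gives 4090 nM, so a modest weakening is the expectation here. The expected step is a 2.5-fold higher number from compound 2 to compound 3 (0.40 log units; beyond the scatter). Compound 3 is estimated at 250 nM, with an expected range of 50 nM to 1200 nM.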

Compound 3, half-maximal inhibitory concentration: 950 nM
Beside the measured number, compound 3's estimate is 3.8-fold (0.58 log units) below it; measured number inside the range.
By their numbers in this assay, from the lowest: compound 2; then compound 3; then compound 1.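

In this assay, for the compounds shown here, the swap of hydroxy for ethylamino on a saturated chain carbon bound to a carbonyl carbon gives a 9.5-fold higher number from compound 2 to compound 3 (0.98 log units; beyond the scatter) and so provides the first direct reading of this change, with the rest of the structure held the same. The activity therefore depends on which group sits at this place, and of the two groups compared here, hydroxy gives the lower number. Nothing measured here gives a reason for this step.

The compounds shown leave open how a plain amine, methylamino or a carboxylic acid would read at this place. They also leave open whether a longer chain ending in hydroxy would match compound 2.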